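Chloro to methoxy on the pendant phenyl of compound 2

A few compounds are considered here, and "the series" means these few. Any claim that something is new, unique, unknown or untested is made for them only; others in the source may bear on it.

Two members of the series have been run in a functional assay on HeLa cells (Homo sapiens) for cytotoxicity, read by MTT assay, with a stated time of 72 h; a lower number here means a stronger inhibitor, a higher number a weaker inhibitor. Compound 1 `O=C1c2cccc([N+](=O)[O-])c2NC[C@@]12[C@H](c1ccc(Cl)cc1)[C@@H](c1ccccc1)N[C@]21C(=O)Nc2ccc(Br)cc21` gives 23000 nM in this assay, and compound 2 `O=C1c2cccc([N+](=O)[O-])c2NC[C@@]12[C@H](c1ccc(Cl)cc1)[C@@H](c1ccccc1)N[C@]21C(=O)Nc2ccc(F)cc21` gives 25000 nM; the change from bromo to fluoro, a 1.1-fold higher number from compound 1 to compound 2 (0.04 log units; within the scatter), leaves the two numbers indistinguishable, so compound 2 sits alongside compound 1 rather than apart from it, and these two values span the whole of what is known. Compound 3 `COc1ccc([C@@H]2[C@@H](c3ccccc3)N[C@]3(C(=O)Nc4ccc(F)cc43)[C@]23CNc2c(cccc2[N+](=O)[O-])C3=O)cc1` differs from compound 2 by methoxy in place of chloro on an aromatic carbon. Going by the values given here, no measured step touches this position; the only step measured, a 1.1-fold higher number from compound 1 to compound 2 (0.04 log units; within the scatter), concerns a different ring and was flat. The expectation for compound 3 in this assay therefore rests on that flatness alone: no change at the digits printed from compound 2 to compound 3 (within the scatter), a step expected to stay within the scatter. Compound 3 is estimated at 25000 nM in this assay, with a range from 8000 nM to 80000 nM.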

Compound 3, half-maximal inhibitory concentration: 24000 nM
Estimate against measurement, compound 3: 1.0-fold (0.02 log units) above; measured number inside the range.
By their numbers in this assay, from the lowest: compounds 1, 3 and 2 (each within the scatter of the next).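

In this assay, the change from 4-chlorophenyl to 4-methoxyphenyl gives a 1.0-fold lower number from compound 2 to compound 3 (0.02 log units; within the scatter), which extends the flat picture from the bromo to fluoro step to a second place on the shared core. At this position, para to a large group, the assay does not separate chloro from methoxy, even though the entering group adds a hydrogen-bond acceptor that the leaving group lacks. No available evidence accounts for this flat result.

As far as these compounds go, whether an amine, a carboxylic acid or a longer chain such as butoxy at this place would also stay within the scatter remains open. The three compounds shown also leave open which change to the shared core, if any, would move the number beyond the scatter in this assay.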